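The compounds below may be only part of what the source reports. "The series", "measured", "known", "first", "only" and "open" are said of these compounds alone.

Compound 1 `COc1ncnc2c1c(I)cn2[C@@H]1O[C@H](CO)[C@@H](O)[C@H]1O`: > 20000 nM
Compound 2 `C#Cc1cn([C@@H]2O[C@H](CO)[C@@H](O)[C@H]2O)c2ncnc(OC)c12`: 300 nM
Compound 3 `Cc1ncnc2c1c(-c1cc3ccccc3o1)cn2[C@@H]1O[C@H](CO)[C@@H](O)[C@H]1O`: 19500 nM
Compound 4 `COc1ncnc2c1c(-c1cc3ccccc3o1)cn2[C@@H]1O[C@H](CO)[C@@H](O)[C@H]1O`: not yet measured

In a functional assay on K562 cells (Homo sapiens), read by MTT assay, with a stated time of 72 h (on this read-out higher numbers stand for weaker inhibition and lower numbers for stronger inhibition), compound 1 gives only a limit, > 20000 nM; this is the limit (the limit of > 20000 nM in this assay, at which 1 of the 3 values shown sits). In this assay compound 2 gives 300 nM. Compound 3 gives 19500 nM, the highest number among the measured compounds, with compound 2 as its nearest neighbour. Among the measured compounds shown here, the one measured step, an at least 66-fold lower number from compound 1 to compound 2 (1.82 log units; beyond the scatter), exchanges the substituent on the five-membered ring and leaves the methoxy group in place.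

Compound 4 differs from compound 3 only on the six-membered ring: methoxy in place of methyl on an aromatic carbon. For the measured compounds named here, no measured step exchanges methyl for methoxy at this position, so the series offers no direct precedent. Compounds 1 and 2 both carry the methoxy group, and between them lies the whole measured range, so the methoxy group on its own is not tied to either end of it. For compound 4 a step of about a 2.0-fold lower number from compound 3 to compound 4 (0.29 log units; within the scatter) is expected, a modest change at most. Compound 4 is estimated at 10000 nM, with a range of 2000 nM to 20000 nM.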

Compound 4, half-maximal inhibitory concentration: 20900 nM
Compound 4: middle estimate off by 2.1-fold (0.32 log units), on the low side; measured number above the stated range.
By their numbers in this assay, from the lowest: compound 2; then compounds 3 and 4 (each within the scatter of the next).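

In this assay, exchanging methyl for methoxy on the six-membered ring gives a 1.1-fold higher number from compound 3 to compound 4 (0.03 log units; within the scatter), so with 1-benzofuran-2-yl on the five-membered ring the two groups are not told apart at this position. With methoxy held constant, the substituent on the five-membered ring accounts for a large difference, a 70-fold higher number from compound 2 to compound 4 (1.84 log units; beyond the scatter), so here ethynyl and 1-benzofuran-2-yl are clearly separated. The step from compound 1 to compound 4 cannot be read because compound 1 gives only a limit: the limit of > 20000 nM in this assay, at which 1 of the 4 values shown sits.

On these data alone, it remains open whether methyl and methoxy would also match with ethynyl on the five-membered ring. As far as these compounds go, it is also open whether an amine or an ethoxy group on the same aromatic carbon would leave the number unchanged.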